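Shifting the Chloro Group on the Amide Phenyl Ring

A few compounds are considered here, and "the series" means these few. Any claim that something is new, unique, unknown or untested is made for them only; others in the source may bear on it.

Compound 1 `COc1cc(-c2cc(C(=O)O)c3ccccc3n2)ccc1OCC(=O)Nc1ccccc1`: in an ADME assay on HaCaT cells (Homo sapiens) for inhibition (on this read-out lower numbers stand for stronger inhibition and higher numbers for weaker inhibition), compound 1 gives only a limit of the assay, > 300000 nM.
Compound 2 `COc1cc(-c2cc(C(=O)O)c3ccccc3n2)ccc1OCC(=O)Nc1ccc(F)cc1`: in this assay compound 2 gives 286000 nM.
Compound 3 `COc1cc(-c2cc(C(=O)O)c3ccccc3n2)ccc1OCC(=O)Nc1ccccc1Cl`: in this assay compound 3 gives 210000 nM.

Among the two real numbers in this assay, compound 3 stands lowest, with compound 2 nearest; the gap between them, a 1.4-fold lower number from compound 2 to compound 3 (0.13 log units; within the scatter), lies within the scatter, so the two cannot be told apart. The other comparisons, an at least 1.0-fold lower number from compound 1 to compound 2 (0.02 log units; that floor lies within the scatter) and an at least 1.4-fold lower number from compound 1 to compound 3 (0.15 log units; that floor lies within the scatter), start from a limit and are likewise within the scatter; the limit of > 300000 nM in this assay, at which 1 of the 3 values shown sits, is where compound 1 sits.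

Compound 4 `COc1cc(-c2cc(C(=O)O)c3ccccc3n2)ccc1OCC(=O)Nc1cccc(Cl)c1` is built from compound 3 by a single change: 3-chlorophenyl in place of 2-chlorophenyl on an amide-type nitrogen. Within the data shown here, no measured step moves a chloro group from one position to another on that ring. The steps that come closest are the swap of fluoro for chloro on the amide-type nitrogen's aryl group, a 1.4-fold lower number from compound 2 to compound 3 (0.13 log units; within the scatter), and the addition of chloro, an at least 1.4-fold lower number from compound 1 to compound 3 (0.15 log units; that floor lies within the scatter), both of which stayed inside the scatter. Compound 4 is therefore expected to show no step beyond the scatter, with a 1.0-fold higher number from compound 3 to compound 4 (0.02 log units; within the scatter) as the estimated change. The estimate for compound 4 is 220000 nM, expected to fall between 100000 nM and 500000 nM.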

Compound 4, half-maximal inhibitory concentration: 192000 nM
The estimate for compound 4 lay 1.1-fold (0.06 log units) above the measured number; the measured number falls inside the stated range.
By their numbers in this assay, from the lowest: compounds 4, 3 and 2 (each within the scatter of the next). At a limit, above all of these: compound 1.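

Among these compounds, this is the first direct comparison of two chloro positions on the ring attached to the amide-type nitrogen, and 3-chlorophenyl in place of 2-chlorophenyl gives a 1.1-fold lower number from compound 3 to compound 4 (0.04 log units; within the scatter), so compound 3 and compound 4 cannot be told apart in this assay; 3-chlorophenyl in place of 4-fluorophenyl gives a 1.5-fold lower number from compound 2 to compound 4 (0.17 log units; within the scatter), so compound 4 cannot be separated from compound 2 either. Chloro in place of hydrogen at this new position gives an at least 1.5-fold lower number from compound 1 to compound 4 (0.19 log units; that floor lies within the scatter), and only this floor can be read, so this comparison does not show a real effect of adding the chloro group. Compound 1 supplies only a limit of the assay, not a number: the limit of > 300000 nM in this assay, at which 1 of the 4 values shown sits.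

Across the 2-chlorophenyl, 3-chlorophenyl and 4-fluorophenyl groups, no measured step lies beyond the scatter, so it remains open whether any replacement on this ring can move the result by a clear margin. An amine or a nitrile in place of the chloro group, or a longer chain between the amide and the shared core, could test this, and the compounds shown say nothing about how such groups would behave.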